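Compound 3: 6-methylpyridin-3-yl for 4-(methylsulfonyl)phenyl

The source may hold more compounds than are shown below. What is called first, only, known or untested is meant among the compounds shown, and "the series" means these compounds.

In an ADME assay (liver) for metabolic stability, with Liver microsome (Rattus norvegicus) as the target, using microsomes and NADPH, with a stated time of 30 min, tested at 1 uM (on this read-out higher numbers stand for fast clearance and lower numbers for slow clearance), compound 2 (`CS(=O)(=O)c1ccc(-c2cc(C(O)(C(F)(F)F)C(F)(F)F)cnc2N2CCN(S(=O)(=O)c3ccc(N)nc3)CC2)cc1`) gives 103 mL.min-1.g-1 and compound 1 (`Nc1ccc(S(=O)(=O)N2CCN(c3ncc(C(O)(C(F)(F)F)C(F)(F)F)cc3-c3cccc(F)c3)CC2)cn1`) gives 52 mL.min-1.g-1 so the two values lie within the scatter of each other. Compound 3 (`Cc1ccc(-c2cc(C(O)(C(F)(F)F)C(F)(F)F)cnc2N2CCN(S(=O)(=O)c3ccc(N)nc3)CC2)cn1`) carries 6-methylpyridin-3-yl in place of 4-(methylsulfonyl)phenyl on an aromatic carbon, ortho to a large group (6-methylpyridin-3-yl in place of 4-(methylsulfonyl)phenyl on an aromatic carbon). Among the measured compounds shown here, one measured step bears on this change. It is a 2.0-fold higher number from compound 1 to compound 2 (0.30 log units; within the scatter) with 4-(methylsulfonyl)phenyl in place of 3-fluorophenyl on that same carbon, and it stays within the scatter. This is thin evidence, resting on a single step with a different pair of groups. The step to be expected is a 1.3-fold lower number from compound 2 to compound 3 (0.11 log units; within the scatter) and no shift beyond the scatter is expected in either direction. In this assay compound 3 is expected at 80 mL.min-1.g-1 with an estimated range from 35 mL.min-1.g-1 to 180 mL.min-1.g-1 on this read-out.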

Compound 3, intrinsic clearance in microsomes: 182 mL.min-1.g-1
Compound 3: middle estimate off by 2.3-fold (0.36 log units), on the low side; the whole stated range lies below it.
By their numbers in this assay, from the lowest: compounds 1, 2 and 3 (each within the scatter of the next, the first and the last beyond it).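

In this assay, the change of aromatic ring on this carbon, ortho to a large group, now gives a step beyond the scatter: a 3.5-fold higher number from compound 1 to compound 3 (0.54 log units; beyond the scatter) for the swap to 6-methylpyridin-3-yl from 3-fluorophenyl, a modest one. The direct exchange gives a 1.8-fold higher number from compound 2 to compound 3 (0.25 log units; within the scatter) and so does not separate 6-methylpyridin-3-yl from 4-(methylsulfonyl)phenyl on this read-out, which leaves only the two ends of the three-compound set apart. Nothing shown accounts for these numbers.

Going by these compounds, all three groups at this carbon are six-membered aromatic rings, so it remains open how a morpholine, an amine or a short alkyl chain there would read. Also open, on these data alone, is whether any group on this carbon reaches a number clearly lower than that of compound 1 at 52 mL.min-1.g-1 on the same read-out.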